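Secondary amines on the growth hormone secretagogue chain

A few compounds are considered here, and "the series" means these few. Any claim that something is new, unique, unknown or untested is made for them only; others in the source may bear on it.

Compound 1 `CC(C)(N)CCC(=O)N[C@@H]1CCc2ccccc2N(Cc2ccc(-c3ccccc3-c3nn[nH]n3)cc2)C1=O`: 3 uM
Compound 2 `NCCC(=O)N[C@@H]1CCc2ccccc2N(Cc2ccc(-c3ccccc3-c3nn[nH]n3)cc2)C1=O`: 2 uM
Compound 3 `CC(C)(CC(=O)N[C@@H]1CCc2ccccc2N(Cc2ccc(-c3ccccc3-c3nn[nH]n3)cc2)C1=O)NCCN`: 230 uM

In a functional assay on cells (Pituitary gland cell) with growth hormone secretagogue receptor type 1 (Rattus norvegicus) as the target (a higher number here means that more compound is needed for the effect, a lower number that less compound is needed), compound 2 gives the lowest number of the three, with compound 1 close by and compound 3 far off. Compound 4 `CC(C)CNC(C)(C)CC(=O)N[C@@H]1CCc2ccccc2N(Cc2ccc(-c3ccccc3-c3nn[nH]n3)cc2)C1=O` carries 1-(isobutylamino)-1-methylethyl in place of aminomethyl on a saturated chain carbon bound to a carbonyl carbon. The step that bears on this is a 120-fold higher number from compound 2 to compound 3 (2.06 log units; beyond the scatter), and likewise a 77-fold higher number from compound 1 to compound 3 (1.88 log units; beyond the scatter), both large and both adding a substituent on the chain nitrogen of a 1-methylethyl group. A similar change with isobutyl instead of 2-aminoethyl is therefore expected to give a higher number in this assay, beyond the scatter, though perhaps less far than compound 3. For compound 4 the estimate is 30 uM, within 5 uM to 200 uM, an expected 15-fold higher number from compound 2 to compound 4 (1.18 log units; beyond the scatter).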

Compound 4, concentration for half-maximal effect: 85 uM
The estimate for compound 4 lay 2.8-fold (0.45 log units) below the measured number; the measured number falls inside the stated range.
By their numbers in this assay, from the lowest: compounds 2 and 1 (each within the scatter of the next); then compound 4; then compound 3.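

In this assay, the isobutyl group also carries a large penalty, with a 43-fold higher number from compound 2 to compound 4 (1.63 log units; beyond the scatter) and a 28-fold higher number from compound 1 to compound 4 (1.45 log units; beyond the scatter), so a large rise is not confined to the 2-aminoethyl group of compound 3. The end of the group on the amine nitrogen still matters modestly: isopropyl in place of aminomethyl gives a 2.7-fold lower number from compound 3 to compound 4 (0.43 log units; beyond the scatter). No measurement here explains these shifts.

The compounds shown leave open whether the rise follows the substituent on the nitrogen or the two methyl groups on the neighbouring carbon. A 1-amino-1-methylethyl group at this place would separate the two.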